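Thiocarbonyl amine variation and antiproliferative read-out

The source may hold more compounds than are shown below. What is called first, only, known or untested is meant among the compounds shown, and "the series" means these compounds.

Values in a functional assay on HeLa cells (Homo sapiens) for antiproliferative activity, read by CCK-8 assay, with a stated time of 72 h, tested at 8 uM; on this read-out lower numbers stand for a weaker effect and higher numbers for a stronger effect at the one concentration tested:
compound 1 `CCN(Cc1ccncc1)C(=S)SCc1ccc(C(=O)Nc2ccccc2N)cc1`: 77.7%
compound 2 `CN1CCN(C(=S)SCc2ccc(C(=O)Nc3ccccc3N)cc2)CC1`: 75.7%
compound 3 `CN(Cc1cccnc1)C(=S)SCc1ccc(C(=O)Nc2ccccc2N)cc1`: 68.7%

Compound 3 has the lowest of the three numbers, yet its gaps to both neighbours, a number 9 percentage points lower from compound 1 to compound 3 (within the scatter) and a number 7 percentage points lower from compound 2 to compound 3 (within the scatter), stay within the scatter, as does a number 2 percentage points lower from compound 1 to compound 2 (within the scatter). Compound 4 `Nc1ccccc1NC(=O)c1ccc(CSC(=S)N2CCCC2)cc1` differs from compound 3 by pyrrolidin-1-yl in place of methyl((pyridin-3-yl)methyl)amino on a thiocarbonyl carbon. Among the measured compounds shown here, the steps that bear on this are the exchanges of one amine for another on the same thiocarbonyl carbon, a number 7 percentage points lower from compound 2 to compound 3 (within the scatter) and a number 2 percentage points lower from compound 1 to compound 2 (within the scatter), neither of which left the scatter. A step of no more than the scatter is therefore expected in this assay, a number 3.3 percentage points higher from compound 3 to compound 4 (within the scatter). Compound 4 is estimated at 72%, between 58% and 84%.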

Compound 4, a percentage reported as inhibition, at one concentration (the size of the read-out at that concentration, not a potency): 77.8%
The estimate for compound 4 lay 5.8 percentage points below the measured number; the measured number falls inside the stated range.
By their numbers in this assay, from the lowest: compounds 3, 2, 1 and 4 (each within the scatter of the next).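

At this thiocarbonyl carbon, pyrrolidin-1-yl, with its one five-membered non-aromatic ring and no hydrogen-bond acceptor, gives steps that all stay within the scatter in this assay: a number 9.1 percentage points higher from compound 3 to compound 4 (within the scatter), a number 2.1 percentage points higher from compound 2 to compound 4 (within the scatter) and a number 0.1 percentage points higher from compound 1 to compound 4 (within the scatter). An amine with neither a pyridine ring nor a second ring nitrogen therefore cannot be told apart from those that carry one. No measured evidence here accounts for this result.

Open, going by these compounds, is whether a morpholine ring or a carboxylic acid on the amine would leave the scatter. Each value gives only the size of the effect at one concentration, and whether the effect would be stronger or weaker at other concentrations remains unresolved.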